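Amide aryl swap in a thioacetamide series: cytotoxicity notes

The source may hold more compounds than are shown below. What is called first, only, known or untested is meant among the compounds shown, and "the series" means these compounds.

Three compounds of the shared core have been run in an ADME assay on MT4 cells (Homo sapiens) for cytotoxicity, read by MTT assay; on this read-out higher numbers stand for lower toxicity in this test and lower numbers for higher toxicity in this test. Compound 1 `Cc1ccccc1NC(=O)CSc1nccn1-c1ccc(Cl)cc1` gives 160000 nM. Compound 2 `Cc1ccc(-n2ccnc2SCC(=O)Nc2ccccc2Cl)cc1` gives 33700 nM, and compound 3 `Cc1ccc(-n2ccnc2SCC(=O)Nc2ccccc2Br)cc1` gives 39300 nM. Among the measured compounds shown here, compound 3 stands second highest of the three numbers, nearest to compound 2 and furthest from compound 1; the one step measured within the set, a 1.2-fold higher number from compound 2 to compound 3 (0.07 log units; within the scatter), shows that the swap of one halogen for another at this position left the read-out essentially unchanged.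

The next compound, compound 4 `Cc1ccc(-n2ccnc2SCC(=O)Nc2ccccc2C)cc1`, is not yet measured. Its difference from compound 3 is methyl in place of bromo on an aromatic carbon, on the same aromatic carbon, ortho to a large group, that carried the halogen in compounds 2 and 3. For the measured compounds named here, no measured step exchanges a halogen for a methyl at this position; compound 1 also carries the (2-methylphenyl)amino group, but it differs from compound 4 elsewhere as well, so its number bears only loosely. Going by the values given here, the only relevant precedent, the step from compound 2 to compound 3, lay within the scatter, and a step of a size within the scatter is therefore expected here too, with no clear direction. Compound 4 is estimated at 45000 nM, range 20000 nM to 110000 nM, which is expected to mean a step of a 1.1-fold higher number from compound 3 to compound 4 (0.06 log units; within the scatter).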

Compound 4, half-maximal cytotoxic concentration: 147000 nM
Compound 4: the middle estimate sits 3.3-fold (0.51 log units) below what was measured, and the stated range ends below it.
By their numbers in this assay, from the lowest: compounds 2 and 3 (each within the scatter of the next); then compounds 4 and 1 (each within the scatter of the next).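

The position is not indifferent to what it carries: in this assay, methyl separates from both halogens (a 3.7-fold higher number from compound 3 to compound 4 (0.57 log units; beyond the scatter); a 4.4-fold higher number from compound 2 to compound 4 (0.64 log units; beyond the scatter)), although the exchange of one halogen for the other stayed within the scatter (a 1.2-fold higher number from compound 2 to compound 3 (0.07 log units; within the scatter)). At this carbon, then, bromo and chloro read alike and methyl reads as the less toxic member of the group, with a modest step in each case. The same kind of exchange, methyl in place of chloro, gives a different outcome at another place in the molecule, where compound 1 and compound 4 lie within the scatter of each other (a 1.1-fold lower number from compound 1 to compound 4 (0.04 log units; within the scatter)), so the effect of this exchange depends on where it is made in these compounds. No supporting measurement is at hand to account for the gap between methyl and the halogens.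

Only methyl and two halogens are shown at this carbon, so it stays open whether the higher number belongs to methyl alone or also extends to groups such as methoxy, ethyl or an amine. As far as these compounds go, whether fluoro would read with the other halogens, or an unsubstituted carbon with methyl, is equally open.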